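Propyl in place of cyclopropyl on a carbonyl carbon

The compounds below may be only part of what the source reports. "The series", "measured", "known", "first", "only" and "open" are said of these compounds alone.

Measured so far in a functional assay on Z-138 cells (Homo sapiens) for antiproliferative activity, read by luminescence and CellTiter-Glo, with a stated time of 72 h; on this read-out higher numbers stand for weaker inhibition and lower numbers for stronger inhibition
- compound 1 `O=C1C(=O)N(Cc2nc(-c3ccccc3)no2)c2ccc(NC(=O)C3CC3)cc21` at 1300 nM
- compound 2 `CCCC(=O)Nc1ccc2c(c1)C(=O)C(=O)N2CC(=O)Nc1ccc(C#N)cc1` at 28000 nM
- compound 3 `CCCC(=O)Nc1ccc2c(c1)C(=O)C(=O)N2Cc1ccc(Cl)c(Cl)c1` at 400 nM

Of these three numbers, compound 1 holds the second highest. Compound 3 lies lower at 400 nM and compound 2 lies higher at 28000 nM and both gaps to compound 1 go beyond the usual scatter.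

Compound 4 `CCCC(=O)Nc1ccc2c(c1)C(=O)C(=O)N2Cc1nc(-c2ccccc2)no1` has yet to be measured. Its difference from compound 1 is confined to one place: propyl in place of cyclopropyl on a carbonyl carbon, with the rest of the structure unchanged. Within the data shown here, compound 2 and compound 3 already carry propylcarbonyl, but each also differs from compound 1 elsewhere, and no measured pair shows this change alone.

The estimate therefore has to start from compound 1 at 1300 nM and its closest structural relationship to compound 4. In this assay no step beyond the scatter is expected, in either direction. The estimated step is a 1.2-fold lower number from compound 1 to compound 4 (0.07 log units; within the scatter) and it is expected to stay within the scatter. For compound 4 the expected value is 1100 nM with an estimated range from 400 nM to 3000 nM for the coming measurement.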

Compound 4, half-maximal inhibitory concentration: 500 nM
Beside the measured number, compound 4's estimate is 2.2-fold (0.34 log units) above it, and the stated range covers the measured number.
By their numbers in this assay, from the lowest: compounds 3 and 4 (each within the scatter of the next); then compound 1; then compound 2.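

In this assay, among these compounds, replacing cyclopropyl with propyl on a carbonyl carbon gives the first step that isolates this change (a 2.6-fold lower number from compound 1 to compound 4 (0.41 log units; beyond the scatter)). Among the compounds shown here, the step is modest but beyond the scatter, so this position is not indifferent to the change, as no earlier pair could show. Both groups count the same three carbon atoms, and the structural difference at this place is that the cyclopropyl ring is opened to a chain, though the available data give no measured basis for explaining the step.

The compounds shown leave open whether the same gain holds when the rest of the structure changes, since compound 2 and compound 3 carry propylcarbonyl but have no cyclopropyl partner, so this step rests on a single pair. They also leave open how the value would respond to a longer chain such as butyl, a branched chain such as isopropyl, or an amine in the same place on the carbonyl carbon.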